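A few compounds are considered here, and "the series" means these few. Any claim that something is new, unique, unknown or untested is made for them only; others in the source may bear on it.

Measured compounds:
Compound 1 `CN(Cc1ccccc1)C(=O)C1CCN(C(=O)c2ccc(S(C)(=O)=O)c([N+](=O)[O-])c2)CC1` — in an assay on isolated protein for inhibition of thyroid hormone receptor alpha (Homo sapiens), read by fluorescence polarization (on this read-out lower numbers stand for stronger inhibition and higher numbers for weaker inhibition), compound 1 gives > 60000 nM, a limit of the assay rather than a number.
Compound 2 `CN1CCN(C(=O)C2CCN(C(=O)c3ccc(S(C)(=O)=O)c([N+](=O)[O-])c3)CC2)CC1` — in this assay compound 2 gives > 60000 nM, again a limit of the assay and not a number.

Compound 2 therefore stands at the edge of what this assay can report; both values shown sit at the limit of > 60000 nM in this assay, at which 2 of the 2 values shown sit, so neither compound has a readable number. For the measured compounds named here, the one measured step, a step that the two limits leave unreadable from compound 1 to compound 2, is left unreadable by the two limits.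

Compound 3 `CS(=O)(=O)c1ccc(C(=O)N2CCC(C(=O)N3CCc4ccccc4C3)CC2)cc1[N+](=O)[O-]` is the compound not yet measured. It differs from compound 2 in one place: 1,2,3,4-tetrahydroisoquinolin-2-yl in place of 4-methylpiperazin-1-yl on a carbonyl carbon. Going by the values given here, the only measured step bears on this change merely by showing that an exchange of the group on this carbonyl carbon between compound 1 and compound 2 gave no readable movement. Nothing here points to a step beyond the scatter in either direction, and the expectation is that compound 3 will again reach only the limit of this assay.

The estimate for compound 3 is 80000 nM, within 20000 nM to 300000 nM, which as a step from compound 2 is expected to be a step that the limit leaves unreadable from compound 2 to compound 3.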

Compound 3, half-maximal inhibitory concentration: > 60000 nM
Compound 3 was reported as a limit; the forecaster's own chance of this, stated with the estimate: 85%; the middle value does not contradict the limit.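

For the compounds shown here, compound 1, compound 2 and compound 3 each reach a limit of this assay and give no number, and no step among them can be read. As far as these compounds go, how strongly any of the three inhibits the receptor stays open, as does whether any other group on this carbonyl carbon would give a readable number.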